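Turning the Thiophene Ring on a Shared Core

The compounds below may be only part of what the source reports. "The series", "measured", "known", "first", "only" and "open" are said of these compounds alone.

Measured compounds:
Compound 1 `Cc1nc(N)c2c(-c3cccs3)cn([C@@H]3O[C@H](CO)[C@@H](O)[C@H]3O)c2n1`; in a functional assay on K562 cells (Homo sapiens), read by MTT assay, with a stated time of 72 h (a higher number here means a weaker inhibitor, a lower number a stronger inhibitor), compound 1 gives only a limit, > 20000 nM.
Compound 2 `COc1nc(N)nc2c1c(-c1cccs1)cn2[C@@H]1O[C@H](CO)[C@@H](O)[C@H]1O`; in this assay compound 2 gives only a limit, > 20000 nM.
Compound 3 `COc1nc(N)nc2c1c(-c1ccoc1)cn2[C@@H]1O[C@H](CO)[C@@H](O)[C@H]1O`; in this assay compound 3 gives only a limit, > 20000 nM.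

Compound 1 therefore stands nowhere in particular on the numbers shown: its result is a limit of the assay, not a measured number, and the same holds for the two companions, as summed up by the limit of > 20000 nM in this assay, at which 3 of the 3 values shown sit. Among the measured compounds shown here, no compound here has a readable value to compare against.

Compound 4 `Cc1nc(N)c2c(-c3ccsc3)cn([C@@H]3O[C@H](CO)[C@@H](O)[C@H]3O)c2n1` differs from compound 1 in one place: thiophen-3-yl in place of thiophen-2-yl on an aromatic carbon. For the measured compounds named here, the only measured step, a step that the two limits leave unreadable from compound 2 to compound 3, also swaps one five-membered ring for another at the same aromatic carbon, but both of its ends are limits, so its size cannot be read. Going by the values given here, no step on record speaks for or against a change of the thiophene attachment point.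

With nothing to build on beyond three limits, compound 4 is expected to behave like compound 1 and most likely to return a limit as well; the expected step that the limit leaves unreadable from compound 1 to compound 4 is no change beyond the scatter. Compound 4 is estimated at 30000 nM, with a range from 6000 nM to 150000 nM.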

Compound 4, half-maximal inhibitory concentration: > 20000 nM
Compound 4 gave a limit, no number (the forecaster's own chance of this, stated with the estimate: 85%); the middle value is on the limit's open side.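

Compound 4 gives only a limit in this assay, > 20000 nM. Compound 1 also gives a limit, so the step between compound 1 and compound 4 cannot be read. All the results shown share one limit: the limit of > 20000 nM in this assay, at which 4 of the 4 values shown sit. The compounds shown leave open whether moving the thiophene attachment point has any effect on potency.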